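A few compounds are considered here, and "the series" means these few. Any claim that something is new, unique, unknown or untested is made for them only; others in the source may bear on it.

Measured compounds in a functional assay on a cell-free system (plasma) for inhibition of thromboxane A2 receptor (Homo sapiens); on this read-out higher numbers stand for weaker inhibition and lower numbers for stronger inhibition:
- compound 1 `CCCCCCSC[C@H]1C2CCC(O2)[C@H]1C/C=C\CCCC(=O)O`: 3800 nM
- compound 3 `CCSCC1C2CCC(O2)C1C/C=C\CCCC(=O)O`: 5400 nM
- compound 2 `CCCCCCSC[C@H]1C2CC[C@@H](O2)[C@H]1C/C=C\CCCC(=O)O`: see below

Compound 2 is recorded three times in this assay as 115000 nM; > 1000000 nM; > 1000000 nM (3 entries). Compound 1 and compound 2 are drawn alike except that one of them carries a defined configuration where the other does not (the fact that one of compounds 1 and 2 is drawn with a defined configuration and the other without, at the place where they differ); beyond the values themselves, nothing further is said about that pair here. Compound 3 holds the higher of the two plain numbers, but its gap to compound 1 lies within the scatter, so no order between compound 1 and compound 3 is claimed.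

The next compound, compound 4 `CC/C=C/CCSCC1C2CCC(O2)C1C/C=C\CCCC(=O)O`, has not yet been run in this assay. Relative to compound 3 it differs by but-1-en-1-yl in place of hydrogen on a saturated chain carbon, two bonds along the chain from a sulfur. Compound 3 sits within the scatter of compound 1, which carries the longer saturated chain on sulfur and stands at 3800 nM, so lengthening the chain at this place has not moved the read-out beyond the usual noise. The step from compound 3 to compound 4 is therefore expected to be a 1.3-fold lower number from compound 3 to compound 4 (0.11 log units; within the scatter), that is, no change beyond the scatter, leaning if at all toward the number of compound 1. Compound 4 is estimated at 4200 nM, with a range from 1500 nM to 12000 nM.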

Compound 4, half-maximal inhibitory concentration: 700 nM
Estimate against measurement, compound 4: 6.0-fold (0.78 log units) above; measured number outside the range, below it.
By their numbers in this assay, from the lowest: compound 4; then compounds 1 and 3 (each within the scatter of the next).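

In this assay, for the compounds shown here, the substituent on sulfur does move the read-out: the change from ethyl to hex-3-en-1-yl, made by but-1-en-1-yl entering in place of hydrogen on a saturated chain carbon, two bonds along the chain from a sulfur, gives a 7.7-fold lower number from compound 3 to compound 4 (0.89 log units; beyond the scatter) and thereby provides the first step read beyond the scatter. The earlier pair gave no such sign, since compound 1, with its longer saturated chain on sulfur, stands within the scatter of compound 3. The entries on compound 2 and the drawing of configuration in compounds 1 and 2 do not bear on this step, so the data offer no explanation for it.

Still open, from the compounds shown here alone, is how much of the step belongs to the double bond and how much to the added carbons, as compound 1 and compound 4 also differ in how their configuration is drawn. Also open, going by these compounds, is how this read-out responds to other groups on sulfur, such as hex-3-yn-1-yl, oct-3-en-1-yl or a chain ending in phenyl, and to hex-3-en-1-yl with the opposite double-bond geometry.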